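A few compounds are considered here, and "the series" means these few. Any claim that something is new, unique, unknown or untested is made for them only; others in the source may bear on it.

Measured in a functional assay with Homo sapiens as the target; on this read-out lower numbers stand for stronger inhibition and higher numbers for weaker inhibition:
- Compound 1 `CC(C)[C@H](NC(=O)COc1cccc2ccccc12)C(=O)N[C@@H](CC(=O)O)C(=O)COc1cccc2ccccc12`: 19000 nM
- Compound 2 `CC(C)[C@H](NC(=O)COc1cccc2ccccc12)C(=O)N[C@@H](CC(=O)O)C(=O)COc1ccc2ccccc2c1`: 15900 nM
- Compound 3 `CC(C)[C@H](NC(=O)COc1cccc2ccccc12)C(=O)N[C@@H](CC(=O)O)C(=O)COc1c(F)cccc1F`: > 100000 nM (a limit, not a number)

For the measured compounds named here, compound 3 stands at a limit of this assay, and the limit of > 100000 nM in this assay, at which 1 of the 3 values shown sits, is the only such value among the three. Its two neighbours give numbers, and a 1.2-fold lower number from compound 1 to compound 2 (0.08 log units; within the scatter) shows no separation between them. Replacing either naphthyl group with 2,6-difluorophenyl gives an at least 5.2-fold higher number from compound 1 to compound 3 (0.72 log units; beyond the scatter) and an at least 6.2-fold higher number from compound 2 to compound 3 (0.79 log units; beyond the scatter), both beyond the scatter.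

Compound 4 `CC(C)[C@H](NC(=O)COc1cccc2ccccc12)C(=O)N[C@@H](CC(=O)O)C(=O)COc1c(F)cc(F)cc1F` has not yet been measured. It carries fluoro in place of hydrogen on an aromatic carbon, meta to two fluoro groups and para to a large group, so 2,6-difluorophenyl becomes 2,4,6-trifluorophenyl: fluoro in place of hydrogen on an aromatic carbon.

Going by the values given here, none of the measured steps adds a fluoro group to this ring. They bear only on the exchange of the whole aryl group, and the data give no direction for this smaller change. No shift beyond the scatter is therefore expected in this assay, and another limit is the likeliest report.

The expected step is a number no higher from compound 3 to compound 4 (the limit leaves the size open).

Compound 4 is estimated at 100000 nM, with an expected range of 40000 nM to 250000 nM.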

Compound 4, half-maximal inhibitory concentration: 14900 nM
The estimate for compound 4 lay 6.7-fold (0.83 log units) above the measured number, outside the stated range (below it).
By their numbers in this assay, from the lowest: compounds 4, 2 and 1 (each within the scatter of the next). At a limit, above all of these: compound 3.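

For the compounds shown here, the single fluoro group, on the aromatic carbon para to a large group and meta to two fluoro groups, gives an at least 6.7-fold lower number from compound 3 to compound 4 (0.82 log units; beyond the scatter), so this position responds to a change of one heavy atom, which the exchanges of the whole aryl group could not show. The 2,4,6-trifluorophenyl group shows no separation from either naphthyl group, with a 1.1-fold lower number from compound 2 to compound 4 (0.03 log units; within the scatter) and a 1.3-fold lower number from compound 1 to compound 4 (0.11 log units; within the scatter), so the loss seen with 2,6-difluorophenyl does not extend to every fluorinated phenyl group here. Compound 3 is the only compound at a limit, which leaves the full size of the step to fluoro open: the limit of > 100000 nM in this assay, at which 1 of the 4 values shown sits.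

On these data alone, whether fluoro itself is needed at this carbon remains open, as chloro or methyl there would test that. Also open, as far as these compounds go, is whether the 2,4,6-trifluorophenyl result holds when an ester takes the place of the carboxylic acid of the shared core.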